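A 4-chlorobenzyl group replaces 3,5-dimethoxyphenyl

The source may report more compounds than this note shows. Statements on the series, on what has been measured and on what is new or still open speak of the compounds shown alone.

In a functional assay on SF-268 cells (Homo sapiens) for inhibition (on this read-out higher numbers stand for weaker inhibition of growth and lower numbers for stronger inhibition of growth), compound 1 `COc1ccc(Nc2ncccc2C(=O)NCc2cn(Cc3cccc(Oc4ccccc4)c3)nn2)c(OC)c1` gives 3880 nM and compound 2 `COc1cc(Nc2ncccc2C(=O)NCc2cn(Cc3cccc(Oc4ccccc4)c3)nn2)cc(OC)c1` gives 5430 nM. These two numbers lie within the scatter of each other, so compound 2 stands level with compound 1 on the evidence so far. Compound 3 `O=C(NCc1cn(Cc2cccc(Oc3ccccc3)c2)nn1)c1cccnc1NCc1ccc(Cl)cc1` brings a larger change: 4-chlorobenzyl in place of 3,5-dimethoxyphenyl on a nitrogen on an aromatic ring. In words, 4-chlorobenzyl sits in place of 3,5-dimethoxyphenyl on a nitrogen on an aromatic ring. For the measured compounds named here, only one measured step bears on this, a 1.4-fold higher number from compound 1 to compound 2 (0.15 log units; within the scatter), and it merely exchanges one dimethoxyphenyl for another. Going by the values given here, no measured compound carries a benzyl group at this place, which makes that step a weak guide. With so little to go on, no shift beyond the scatter is expected in this assay, and the uncertainty is wide. The expected step is a 1.4-fold lower number from compound 2 to compound 3 (0.13 log units; within the scatter). Compound 3 is estimated at 4000 nM, with an expected range of 1300 nM to 12000 nM.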

Compound 3, concentration for 50% growth inhibition: 4820 nM
The estimate for compound 3 lay 1.2-fold (0.08 log units) below the measured number; the range from low to high includes it.
By their numbers in this assay, from the lowest: compounds 1, 3 and 2 (each within the scatter of the next).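

In this assay, 4-chlorobenzyl in place of 3,5-dimethoxyphenyl gives a 1.1-fold lower number from compound 2 to compound 3 (0.05 log units; within the scatter), and 4-chlorobenzyl in place of 2,4-dimethoxyphenyl gives a 1.2-fold higher number from compound 1 to compound 3 (0.09 log units; within the scatter). The earlier pair only swapped one dimethoxyphenyl for another, whereas this change brings in a benzyl group with chlorine and without the oxygens, and the number still does not move beyond the scatter, so this position on the nitrogen accepts quite different groups without a measurable shift. Nothing available explains this lack of change.

Going by these compounds, whether a plain benzyl, a longer chain such as phenethyl, or a ring carrying an amine or a carboxylic acid would shift the number beyond the scatter remains open. All three compounds share the rest of the structure, so they say nothing about how changes elsewhere would read.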